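The source may report more compounds than this note shows. Statements on the series, on what has been measured and on what is new or still open speak of the compounds shown alone.

Measured in an ADME assay on liver for metabolic stability, with Liver microsome (Rattus norvegicus) as the target, read by LC-MS, using microsomes, with a stated time of 5 h; on this read-out higher numbers stand for fast clearance and lower numbers for slow clearance:
- Compound 1 `C[C@]1(c2ccc(OC(F)(F)F)cc2)C[C@@](O)(c2ccccn2)CO1`: 150 mL/min/kg
- Compound 2 `C[C@@]1(c2ccc(OC(F)(F)F)cc2)C[C@@](O)(c2ccccn2)CO1`: 333 mL/min/kg
- Compound 3 `C[C@@]1(c2ccc(OC(F)(F)F)cc2)C[C@](O)(c2ccccn2)CO1`: 383 mL/min/kg

Compound 3 sits level with compound 2 within the scatter, as a 1.2-fold higher number from compound 2 to compound 3 (0.06 log units; within the scatter) shows. It stands clearly above compound 1, with a 2.6-fold higher number from compound 1 to compound 3 (0.41 log units; beyond the scatter) beyond the scatter.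

The next compound is compound 4 `C[C@]1(c2ccc(OC(F)(F)F)cc2)C[C@](O)(c2ccccn2)CO1`, and the change is the two compounds have the same atoms and bonds and differ only in configuration as drawn: 1 of 2 stereo elements differ; a stereocentre at a saturated ring carbon is drawn S in compound 3 and R in compound 4. Going by the values given here, the closest precedent is a 2.2-fold higher number from compound 1 to compound 2 (0.35 log units; beyond the scatter), which also concerns a stereocentre at a saturated ring carbon. It is the same centre, there drawn R in compound 1 and S in compound 2, so the step to compound 4 runs the opposite way. The other single-centre step, a 1.2-fold higher number from compound 2 to compound 3 (0.06 log units; within the scatter), stayed within the scatter and involved the other centre. A modest fall in clearance in this assay is therefore expected, although the precedent comes from the other configuration at the second centre. The expected step is a 1.9-fold lower number from compound 3 to compound 4 (0.28 log units; within the scatter). For compound 4 the estimated clearance is 200 mL/min/kg, with an expected range of 105 mL/min/kg to 380 mL/min/kg.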

Compound 4, clearance: 167 mL/min/kg
Compound 4: the middle estimate sits 1.2-fold (0.08 log units) above what was measured, within the range that was stated.
By their numbers in this assay, from the lowest: compounds 1, 4, 2 and 3 (each within the scatter of the next, the first and the last beyond it).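

In this assay, inverting the same stereocentre that separated compound 1 from compound 2 gives a 2.3-fold lower number from compound 3 to compound 4 (0.36 log units; beyond the scatter), so this centre shifts clearance with the other centre in either configuration, and the shift can be tied to configuration alone because nothing else changes: the fact that compounds 3 and 4 differ only in the configuration as drawn

Inverting the other centre gives a 1.1-fold higher number from compound 1 to compound 4 (0.05 log units; within the scatter), which leaves the two compounds level, as was already seen for compound 2 and compound 3. The newly completed mirror-image pair gives a 2.0-fold lower number from compound 2 to compound 4 (0.30 log units; within the scatter), within the scatter, unlike compound 1 and compound 3, so this pair goes against a clean split into two levels.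

The compounds shown leave open whether this stereocentre would still matter with an amine or a carboxylic acid on the shared core. They also do not show which part of the molecule is cleared.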